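The source may report more compounds than this note shows. Statements on the series, on what has been measured and on what is new or still open speak of the compounds shown alone.

Measured so far:
Compound 1, `COc1ccc(S(=O)(=O)c2cnc3cc(Cl)ccc3c2N2CCC(C)CC2)cc1Cl`: 93%
Compound 2, `CC1CCN(c2c(S(=O)(=O)c3cc(F)cc(F)c3)cnc3c(F)cccc23)CC1`: 9%

In an assay on isolated protein for displacement of a labelled ligand from metabotropic glutamate receptor 5 (Homo sapiens), with a stated time of 60 min, tested at 1 uM (on this read-out higher numbers stand for more inhibition at the one concentration tested (going by the name of the read-out) and lower numbers for less inhibition), compound 1 gives the higher of the two numbers; compound 2 stands far lower, a gap well beyond the usual scatter. Compound 3, `CC1CCN(c2c(S(=O)(=O)c3cc(F)cc(F)c3)cnc3cc(Cl)ccc23)CC1`, has not yet been measured. It differs from compound 1 in one place: 3,5-difluorophenyl in place of 3-chloro-4-methoxyphenyl on a sulfonyl sulfur. Among the measured compounds shown here, no measured pair shows this exact change, but compound 2, which carries the same 3,5-difluorophenyl group on its sulfonyl sulfur, gives only 9% in this assay. A large downward step is therefore expected, a number 63 percentage points lower from compound 1 to compound 3 (beyond the scatter). Compound 3 is estimated at 30%, within a range from 5% to 70%.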

Compound 3, a percentage reported as inhibition, at one concentration (the size of the read-out at that concentration, not a potency): 94%
The estimate for compound 3 lay 64 percentage points below the measured number; the whole stated range lies below it.
By their numbers in this assay, from the lowest: compound 2; then compounds 1 and 3 (each within the scatter of the next).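

In this assay, the change on the sulfonyl sulfur in the core of compound 1 leaves the read-out unmoved, with a number 1 percentage points higher from compound 1 to compound 3 (within the scatter). The 3,5-difluorophenyl group therefore does not by itself bring a low number, which compound 2 alone had left possible. Nothing available explains why the two groups read alike. Being single-concentration readings, these numbers do not show whether potency also matches. As far as these compounds go, it remains open whether a carboxylic acid or amine on this phenyl ring, or a plain butyl chain in its place, would hold the read-out.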